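Shifting a Hydroxyl: From Compound 3 to Compound 4

A few compounds are considered here, and "the series" means these few. Any claim that something is new, unique, unknown or untested is made for them only; others in the source may bear on it.

Compound 1 `Oc1ccc(-c2cc(-c3cccs3)cc(-c3cccc(O)c3)n2)cc1`: 780 nM
Compound 2 `Oc1cccc(-c2cc(-c3ccco3)cc(-c3ccccc3O)n2)c1`: 820 nM
Compound 3 `Oc1ccc(-c2cc(-c3ccco3)cc(-c3ccccc3O)n2)cc1`: > 50000 nM

In a functional assay on T47D cells (Homo sapiens) for cytotoxicity, read by CCK-8 assay (a lower number here means a stronger inhibitor, a higher number a weaker inhibitor), compound 1 gives 780 nM and compound 2 gives 820 nM. For compound 3 the result is only a limit of the assay, > 50000 nM. That value sits at the limit of > 50000 nM in this assay, at which 1 of the 3 values shown sits, so compound 3 stands at the weak end of what has been measured. Compound 4 `Oc1ccc(-c2cc(-c3ccco3)cc(-c3cccc(O)c3)n2)cc1` differs from compound 3 in one place: 3-hydroxyphenyl in place of 2-hydroxyphenyl on an aromatic carbon. Within the data shown here, one measured step bears on this: an at least 60-fold higher number from compound 2 to compound 3 (1.78 log units; beyond the scatter), a shift of one hydroxyl on the shared core that was very costly. The change to compound 4 reverses that kind of shift, giving the same pairing of 4-hydroxyphenyl and 3-hydroxyphenyl found in compound 1, which is potent. A large gain is therefore expected, an at least 33-fold lower number from compound 3 to compound 4 (1.52 log units; beyond the scatter). Compound 4 is estimated at 1500 nM (range 400 nM to 20000 nM).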

Compound 4, half-maximal inhibitory concentration: 1280 nM
The estimate for compound 4 lay 1.2-fold (0.07 log units) above the measured number; measured number inside the range.
By their numbers in this assay, from the lowest: compounds 1, 2 and 4 (each within the scatter of the next). At a limit, above all of these: compound 3.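

On the shared core carrying furan-2-yl and 4-hydroxyphenyl, the group next to the ring nitrogen decides the outcome: 3-hydroxyphenyl in place of 2-hydroxyphenyl gives an at least 39-fold lower number from compound 3 to compound 4 (1.59 log units; beyond the scatter). Once a 3-hydroxyphenyl group is present, the other two changes make no clear difference: 2-hydroxyphenyl and 4-hydroxyphenyl give a 1.6-fold higher number from compound 2 to compound 4 (0.19 log units; within the scatter), and thiophen-2-yl and furan-2-yl give a 1.6-fold higher number from compound 1 to compound 4 (0.22 log units; within the scatter). The first step is only a bound, as the value for compound 3 is a limit: the limit of > 50000 nM in this assay, at which 1 of the 4 values shown sits.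

Going by these compounds, what a methoxy group or an amine would do in place of either hydroxyl remains open.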